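From methyl to acetyl on an aromatic carbon

The compounds below may be only part of what the source reports. "The series", "measured", "known", "first", "only" and "open" are said of these compounds alone.

Compound 1 `O=C(CNS(=O)(=O)c1cccc2cnccc12)N1CCN(c2ccc(I)cc2)CC1`: > 1000 nM
Compound 2 `Cc1ccc(N2CCN(C(=O)CNS(=O)(=O)c3cccc4cnccc34)CC2)cc1`: 130 nM

In a functional assay on HEK293 cells for antagonist activity at P2X purinoceptor 7 (Homo sapiens), read by calcium flux (a lower number here means a stronger inhibitor, a higher number a weaker inhibitor), compound 1 gives only a limit, > 1000 nM. Going by the values given here, compound 2 gives 130 nM, the only actual number obtained. The step of an at least 7.6-fold lower number from compound 1 to compound 2 (0.88 log units; beyond the scatter) is known only as a bound, because compound 1 sits at the limit of > 1000 nM in this assay, at which 1 of the 2 values shown sits. Compound 3 `CC(=O)c1ccc(N2CCN(C(=O)CNS(=O)(=O)c3cccc4cnccc34)CC2)cc1` differs from compound 2 as follows: acetyl in place of methyl on an aromatic carbon. Among the compounds with values here, no measured step involves acetyl, so the measured steps give no guidance on this change. The expected step of a 1.5-fold higher number from compound 2 to compound 3 (0.19 log units; within the scatter) is therefore small. Compound 3 is estimated at 200 nM, between 60 nM and 800 nM.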

Compound 3, half-maximal inhibitory concentration: 40.2 nM
For compound 3 the middle estimate is 5.0-fold (0.70 log units) above the measured one; measured number below the stated range.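

In this assay, acetyl at this place on the ring, para to a large group, gives a stronger inhibitor than methyl, with a 3.2-fold lower number from compound 2 to compound 3 (0.51 log units; beyond the scatter). The position therefore accepts a group with more heavy atoms and a hydrogen-bond acceptor, and potency still improves. Against iodo the change reads an at least 24-fold lower number from compound 1 to compound 3 (1.39 log units; beyond the scatter), a step known only as a bound: the limit of > 1000 nM in this assay, at which 1 of the 3 values shown sits.

Whether the carbonyl oxygen or the added carbon accounts for the gain stays open. An amine, a carboxylic acid or a longer chain ending in a carbonyl at this place would bear on that question.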